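From bromo to methyl on the shared core

A few compounds are considered here, and "the series" means these few. Any claim that something is new, unique, unknown or untested is made for them only; others in the source may bear on it.

In a functional assay on SK-N-SH cells (Homo sapiens) for inhibition (on this read-out higher numbers stand for weaker inhibition of growth and lower numbers for stronger inhibition of growth), compound 1 `O=c1c2cc([N+](=O)[O-])cnc2sn1-c1ccc(Br)cc1` gives 53500 nM, while compound 2 `O=c1c2cccnc2sn1-c1ccc(Br)cc1` gives 15200 nM, the lower of the two numbers. Compound 3 `Cc1ccc(-n2sc3ncccc3c2=O)cc1` differs from compound 2 by methyl in place of bromo on an aromatic carbon, with methyl in place of bromo on an aromatic carbon. Among the measured compounds shown here, the only measured step, a 3.5-fold lower number from compound 1 to compound 2 (0.55 log units; beyond the scatter), is modest and puts hydrogen in place of nitro, so it says little about this different swap. No step beyond the scatter is therefore expected in this assay, in either direction. The estimated change is a 1.1-fold higher number from compound 2 to compound 3 (0.05 log units; within the scatter). For compound 3 the expected value is 17000 nM, with an estimated range of 7000 nM to 42000 nM.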

Compound 3, concentration for 50% growth inhibition: 6200 nM
Compound 3: the middle estimate sits 2.7-fold (0.44 log units) above what was measured; measured number below the stated range.
By their numbers in this assay, from the lowest: compound 3; then compound 2; then compound 1.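

At this place on the six-membered aromatic ring of carbon only, para to a large group, methyl in place of bromo gives a 2.5-fold lower number from compound 2 to compound 3 (0.39 log units; beyond the scatter) in this assay. This position therefore responds to a swap of one heavy atom for another, and methyl goes with stronger inhibition of growth than bromo. The data shown offer no explanation for this shift. Going by these compounds, whether an amine, a methoxy group or a longer chain here would lower the number further remains open. So does whether the same swap would act alike on the core of compound 1, which carries a nitro group.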